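A few compounds are considered here, and "the series" means these few. Any claim that something is new, unique, unknown or untested is made for them only; others in the source may bear on it.

Measured compounds:
- Compound 1 `CN(C)CC[C@H](CSc1ccccc1)Nc1ccc(S(=O)(=O)NC(=O)c2ccc(N3CCN(Cc4ccccc4-c4ccc(Cl)cc4)CC3)cc2)cc1`: in an assay on isolated protein for displacement of a labelled ligand from Apoptosis regulator Bcl-2 (Homo sapiens), read by fluorescence polarization (on this read-out lower numbers stand for stronger inhibition and higher numbers for weaker inhibition), compound 1 gives < 1 nM, which is a limit of the assay rather than a number.
- Compound 2 `CN(C)CC[C@H](CSc1ccccc1)Nc1ccc(S(=O)(=O)NC(=O)c2ccc(N3CCN(Cc4ccccc4-c4ccc(Cl)cc4)CC3)cc2)cc1S(=O)(=O)C(F)(F)F`: in this assay compound 2 gives < 1 nM, again only a limit.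

Compound 2 therefore stands at the limit of < 1 nM in this assay, at which 2 of the 2 values shown sit, with no exact number. Among the compounds with values here, the one measured step, a step that the two limits leave unreadable from compound 1 to compound 2, cannot be read in size for the same reason. The change to compound 3 `CN(C)CC[C@H](CSc1ccccc1)Nc1ccc(S(=O)(=O)NC(=O)c2ccc(N3CCN(Cc4ccccc4-c4ccc(Cl)cc4)CC3)cc2)cc1C#N` is cyano in place of (trifluoromethyl)sulfonyl on an aromatic carbon. With no readable step to draw on, compound 3 is expected to remain near the limit, estimated at 1 nM (range 0.2 nM to 5 nM), a step of a number no lower from compound 2 to compound 3 (the limit leaves the size open).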

Compound 3, inhibition constant: < 1 nM
Compound 3 was reported as a limit; the forecaster's own chance of this, stated with the estimate: 50%; the middle value sits exactly at the limit.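

Within the data shown here, no step among compound 1, compound 2 and compound 3 can be read in size, because all three sit at the same limit: the limit of < 1 nM in this assay, at which 3 of the 3 values shown sit. As far as these compounds go, whether hydrogen, (trifluoromethyl)sulfonyl or cyano at this place makes any difference in this assay stays open.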